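Capping a Hydroxyl in a Glutamate Receptor Antagonist Series

The source may report more compounds than this note shows. Statements on the series, on what has been measured and on what is new or still open speak of the compounds shown alone.

Compound 3 `OCCOc1cc2c(NC3CCCCC3)ncnc2cn1` gives 177 nM in a functional assay on CHO cells for antagonist activity at metabotropic glutamate receptor 1 (Rattus norvegicus), with a stated time of 5 min (on this read-out higher numbers stand for weaker inhibition and lower numbers for stronger inhibition), the lowest of the three numbers recorded. Compound 1 `CN(C)c1cc2c(NC3CCCCC3)ncnc2cn1` gives 199 nM in this assay, and a 1.1-fold lower number from compound 1 to compound 3 (0.05 log units; within the scatter). Compound 2 `C[C@H](Nc1ncnc2cnc(N(C)C)cc12)c1ccccc1` gives 1400 nM in this assay, a gap to compound 3 that lies beyond the scatter.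

Compound 4 `COCCOc1cc2c(NC3CCCCC3)ncnc2cn1` differs from compound 3 by methyl in place of hydrogen on an oxygen on a saturated carbon, that is, hydroxy to methoxy. For the measured compounds named here, no measured pair shows this change; the one measured step, exchanging groups on the aromatic carbon, stayed within the scatter, which gives no reason to expect a large shift here. For compound 4 the expected step is a 1.1-fold higher number from compound 3 to compound 4 (0.05 log units; within the scatter), within the scatter. Compound 4 is therefore estimated at 200 nM, with a range from 70 nM to 600 nM.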

Compound 4, inhibition constant: 101 nM
Compound 4: middle estimate off by 2.0-fold (0.30 log units), on the high side; measured number inside the range.
By their numbers in this assay, from the lowest: compounds 4, 3 and 1 (each within the scatter of the next); then compound 2.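

In this assay methyl in place of the hydrogen on this oxygen gives a 1.8-fold lower number from compound 3 to compound 4 (0.24 log units; within the scatter) and so shows that the hydroxy end of the chain can be capped without leaving the scatter. Measured against the dimethylamino group, the 2-methoxyethoxy group gives a 2.0-fold lower number from compound 1 to compound 4 (0.29 log units; within the scatter) and so all three groups on this aromatic carbon still read alike. No evidence bears on the reason for this result. From the compounds shown here alone, whether an amine or a carboxylic acid at the end of this chain, or a longer chain, would read the same remains open.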